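Widening the ring on the benzimidazole-side chain of compound 1

The source may hold more compounds than are shown below. What is called first, only, known or untested is meant among the compounds shown, and "the series" means these compounds.

Compound 1 `CN(Cc1nc2ccccc2n1CC1CNC1)C1CCCc2cccnc21` is one of a small set of compounds tested in an ADME assay on HOS cells (Homo sapiens) for cytotoxicity; a lower number here means that less compound is tolerated, a higher number that more compound is tolerated. Compound 1 gives 15000 nM, the highest of the two readable numbers. Compound 2 `CN1CCC[C@H](Cn2c(CN(C)[C@H]3CCCc4cccnc43)nc3ccccc32)C1` gives 3600 nM in this assay, a lower number than compound 1 by a margin beyond the scatter. Compound 3 `CC(C)CN1CCC[C@H](Cn2c(CN(C)[C@H]3CCCc4cccnc43)nc3ccccc32)C1` is reported in this assay only as a limit, > 2000 nM, and not as a number. Going by the values given here, the only step between neighbouring compounds, a step that the limit leaves unreadable from compound 2 to compound 3, is therefore unreadable, and the evidence the limit of > 2000 nM in this assay, at which 1 of the 3 values shown sits, records that one of the three values rests on that limit.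

The step from compound 1 to compound 4 `CN1CCCC(Cn2c(CN(C)C3CCCc4cccnc43)nc3ccccc32)C1` is 1-methylpiperidin-3-yl in place of azetidin-3-yl on a saturated chain carbon bound to an aromatic nitrogen. Among the compounds with values here, no measured step covers this change directly; the nearest guide is the pair of compound 1 and compound 2, which differ at the same place by the same groups while compound 2 carries defined stereocentres, and whose values show a lower number for compound 2. Compound 4 is therefore expected to sit near compound 2 in this assay, with a step of a 3.3-fold lower number from compound 1 to compound 4 (0.52 log units; beyond the scatter) downward and beyond the scatter. The estimate for compound 4 is 4500 nM, within 1500 nM to 13000 nM.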

Compound 4, half-maximal cytotoxic concentration: 3000 nM
The estimate for compound 4 lay 1.5-fold (0.18 log units) above the measured number, and the stated range covers the measured number.
By their numbers in this assay, from the lowest: compounds 4 and 2 (each within the scatter of the next); then compound 1.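

In this assay, widening azetidin-3-yl to 1-methylpiperidin-3-yl on a saturated chain carbon bound to an aromatic nitrogen now stands as a direct comparison with no configuration drawn on either compound, and it gives a 5.0-fold lower number from compound 1 to compound 4 (0.70 log units; beyond the scatter). This exchange also replaces a group with 1 hydrogen-bond donor by one with 0 hydrogen-bond donors, although the result cannot show whether that loss matters. Drawing the two stereocentres makes no difference beyond the scatter, with a 1.2-fold lower number from compound 2 to compound 4 (0.08 log units; within the scatter), and the only thing that separates this pair is a matter of drawing: the fact that one of compounds 2 and 4 is drawn with a defined configuration and the other without, at the place where they differ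

On these data alone, the step to compound 3 cannot be read, as the value of compound 3 is a limit: the limit of > 2000 nM in this assay, at which 1 of the 4 values shown sits. The step from azetidin-3-yl to 1-methylpiperidin-3-yl joins a wider ring to a methyl on the ring nitrogen, and how much each part counts remains open; a piperidin-3-yl group without that methyl, or a 1-methylazetidin-3-yl group, would separate the two.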